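Propargyl for Cyclopropyl on the Amide Nitrogen

A few compounds are considered here, and "the series" means these few. Any claim that something is new, unique, unknown or untested is made for them only; others in the source may bear on it.

Compound 2 `C/C(C(=O)NC1CC1)=C(/C)c1ccc(F)cc1` gives 110 mg/kg in a toxicity assay on the whole organism (strain Icem-CET (SPF Caw)) for cytotoxicity, with Mus musculus as the target; on this read-out higher numbers stand for an effect only at larger amounts of compound and lower numbers for an effect already at smaller amounts. Among the three measured compounds it holds the second highest number. Its nearest neighbour is compound 1 `C/C(C(=O)NC1CC1)=C(/C)c1ccc(Br)cc1`, which gives 100 mg/kg; a 1.1-fold higher number from compound 1 to compound 2 (0.04 log units; within the scatter), so the two lie within the scatter. The furthest is compound 3 `C/C(C(=O)NC1CC1)=C(/C)c1ccc(Cl)cc1`, which gives 350 mg/kg; a 3.2-fold higher number from compound 2 to compound 3 (0.50 log units; beyond the scatter), and likewise a 3.5-fold higher number from compound 1 to compound 3 (0.54 log units; beyond the scatter). Compound 4 `C#CCNC(=O)/C(C)=C(\C)c1ccc(F)cc1` differs from compound 2 by propargyl in place of cyclopropyl on an amide-type nitrogen. For the measured compounds named here, all three measured steps concern a halogen on the aromatic carbon and none touches the group on the amide-type nitrogen, so no measured step bears directly on this change. The data give no ground for expecting a shift in either direction. The expected step is no change at the digits printed from compound 2 to compound 4 (within the scatter), with no movement beyond the scatter foreseen and a wide range to reflect the lack of guidance. The estimate for compound 4 in this assay is 110 mg/kg, with a range from 45 mg/kg to 270 mg/kg.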

Compound 4, dose for half-maximal effect: 100 mg/kg
For compound 4 the middle estimate is 1.1-fold (0.04 log units) above the measured one; measured number inside the range.
By their numbers in this assay, from the lowest: compounds 1, 4 and 2 (each within the scatter of the next); then compound 3.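

In this assay, for the compounds shown here, the step at the amide-type nitrogen is a 1.1-fold lower number from compound 2 to compound 4 (0.04 log units; within the scatter), the first reading at this position, and it shows that propargyl can stand in place of cyclopropyl with the two numbers remaining within the scatter. An open chain with a triple bond thus reads alike to a three-membered ring here, on the fluoro compound, whereas the halogen swap a 3.2-fold higher number from compound 2 to compound 3 (0.50 log units; beyond the scatter) lies beyond the scatter. No supporting measurement bears on this result.

The compounds shown leave open whether propargyl and cyclopropyl also read alike when bromo or chloro sits on the aromatic carbon. They also leave open how a longer chain, an amine or a carboxylic acid on the group at the amide-type nitrogen would read in this assay.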